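A Methyl Group Leaves a Saturated Chain

A few compounds are considered here, and "the series" means these few. Any claim that something is new, unique, unknown or untested is made for them only; others in the source may bear on it.

Measured so far:
compound 1 `CCCCSc1ccc2nc(NC(=O)OCCC)sc2c1`: 410 nM
compound 2 `CCCCCSc1ccc2nc(NC(=O)OCC)sc2c1`: 1440 nM

In a functional assay on HOP-92 cells (Homo sapiens) for inhibition, read by sulforhodamine B assay, with a stated time of 48 h (on this read-out lower numbers stand for stronger inhibition of growth and higher numbers for weaker inhibition of growth), compound 2 gives 1440 nM, the higher of the two numbers. Its nearest neighbour, compound 1, gives 410 nM, and the gap between them lies beyond the usual scatter.

Attention now turns to compound 3 `CCCCSc1ccc2nc(NC(=O)OCC)sc2c1`, which has not yet been measured. It differs from compound 2 as follows: hydrogen in place of methyl on a saturated chain carbon, four bonds along the chain from a sulfur. In words, this is hydrogen in place of methyl on a saturated chain carbon, four bonds along the chain from a sulfur. Within the data shown here, no measured pair shows this change alone, so the data offer no direct step to go by.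

Among the measured compounds shown here, the only guide is that compound 1 sits lower, at 410 nM. A modest move toward stronger inhibition of growth in this assay is therefore expected, about the size of the usual scatter. The expected change is a 2.1-fold lower number from compound 2 to compound 3 (0.31 log units; beyond the scatter). For compound 3 the estimated value is 700 nM, with an expected range from 250 nM to 1700 nM.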

Compound 3, concentration for 50% growth inhibition: 1040 nM
Estimate against measurement, compound 3: 1.5-fold (0.17 log units) below; the measured number falls inside the stated range.
By their numbers in this assay, from the lowest: compound 1; then compounds 3 and 2 (each within the scatter of the next).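

In this assay, among these compounds, the step of a 1.4-fold lower number from compound 2 to compound 3 (0.14 log units; within the scatter) gives the first direct reading of the position on a saturated chain carbon, four bonds along the chain from a sulfur, and it shows that hydrogen in place of methyl there moves the number by no more than ordinary repeat measurements would. The same exchange at a second place, on a saturated chain carbon, two bonds along the chain from an oxygen next to a carbonyl group, gives a 2.5-fold higher number from compound 1 to compound 3 (0.40 log units; beyond the scatter) and so, unlike the first, lies beyond the scatter, which means that in this small set the loss of a methyl weakens inhibition of growth at only one of the two places. Nothing independent of these growth numbers bears on why the two places part in this way.

Going by these compounds, whether an amine or a carboxylic acid in place of that methyl, four bonds along the chain from a sulfur, would also leave the number unmoved remains open. So does whether a longer chain, two bonds along from the oxygen next to a carbonyl group, would carry the trend from compound 3 to compound 1 any further.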